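The compounds below may be only part of what the source reports. "The series", "measured", "known", "first", "only" and "open" are said of these compounds alone.

Compound 1 `O=C(O)c1ccc2nc(CN3CCC[C@H](O[C@H](CO)c4cc(Cl)cc(Cl)c4)[C@@H]3c3ccccc3)[nH]c2c1`: 380 nM
Compound 2 `Cc1cc(C(=O)O)ccc1CN1CCC[C@H](O[C@H](CO)c2cc(Cl)cc(Cl)c2)[C@@H]1c1cccnc1`: 47000 nM
Compound 3 `Cc1cc(C(=O)O)ccc1CN1CCC[C@H](O[C@H](CO)c2ccccc2)[C@@H]1c1ccccc1`: 25000 nM

Of the compounds shown here, three have been measured in an assay on isolated protein for activation of cGMP-dependent protein kinase 1 (Homo sapiens), read by ADP-Glo, with stated times of 30 min and 2 h, in the presence of a further agent that is not named here; on this read-out lower numbers stand for an effect already at smaller amounts and higher numbers for an effect only at larger amounts of compound. Among them compound 1 stands with the lowest number. The nearest of the other two is compound 3, and compound 2 lies furthest away; both of these gaps are beyond the scatter of repeated measurements, so compound 1 is set apart from the other two in this assay.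

Compound 4 `OC[C@@H](O[C@H]1CCCN(Cc2nc3ccccc3[nH]2)[C@H]1c1ccccc1)c1cc(Cl)cc(Cl)c1` has not yet been measured in this assay. It differs from compound 1 in one place only: hydrogen in place of carboxy on an aromatic carbon. Among the compounds with values here, no step between two measured compounds shows this same change, so there is no directly comparable pair on which to lean. Within the data shown here, what can be said is that compound 1, the only measured compound carrying this carboxy, gives the lowest number of the three, whereas compounds 2 and 3, which differ from compound 1 in more than one place, give much higher numbers. On this footing the step of a 7.9-fold higher number from compound 1 to compound 4 (0.90 log units; beyond the scatter) is expected to run toward a higher number, beyond the scatter. For compound 4 the estimate in this assay is 3000 nM, with a range from 600 nM to 20000 nM.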

Compound 4, half-maximal effective concentration: 4700 nM
Compound 4: middle estimate off by 1.6-fold (0.19 log units), on the low side; measured number inside the range.
By their numbers in this assay, from the lowest: compound 1; then compound 4; then compounds 3 and 2 (each within the scatter of the next).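

In this assay, hydrogen in place of carboxy on an aromatic carbon of the six-membered aromatic ring of carbon only gives a 12-fold higher number from compound 1 to compound 4 (1.09 log units; beyond the scatter), a large step beyond the scatter. Compounds 2 and 3 differ from compound 1 in more than one place and so could not separate the carboxy from other changes, whereas this single-place pair shows that, with the rest of compound 1 held fixed, the number depends strongly on this one group, yet compound 4 still gives a finite reading of 4700 nM without it. Nothing given here explains why this exchange has so large an effect.

From the compounds shown here alone, whether the carboxy itself is needed, or whether another group on the same aromatic carbon could give a similar number, stays open: a carboxamide, a methyl ester, a tetrazole or an aminomethyl group would each test this. Also open, going by these compounds, is whether a carboxy on another carbon of that ring would match compound 1, and whether the same exchange would have a step of similar size on a different core.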